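Chloro Replaced by Methyl in an Amide Series

A few compounds are considered here, and "the series" means these few. Any claim that something is new, unique, unknown or untested is made for them only; others in the source may bear on it.

For the measured compounds named here, compound 2 `O=C(Nc1c(C(O)(C(F)(F)F)C(F)(F)F)ccc2ccccc12)c1ccccc1Cl` has the lower of the two numbers measured so far in an assay on LtK cells with ATP-sensitive inward rectifier potassium channel 11 (Homo sapiens) as the target (a lower number here means that less compound is needed, a higher number that more compound is needed for the effect), where compound 2 gives 2040 nM. Going by the values given here, its only measured neighbour, compound 1 `CCC(C)C(=O)Nc1c(C(O)(C(F)(F)F)C(F)(F)F)ccc2ccccc12`, gives 177000 nM in this assay. Among the compounds with values here, the single measured step, an 87-fold lower number from compound 1 to compound 2 (1.94 log units; beyond the scatter), exchanges the sec-butyl group on the carbonyl carbon for a 2-chlorophenyl ring. Compound 3 `Cc1ccccc1C(=O)Nc1c(C(O)(C(F)(F)F)C(F)(F)F)ccc2ccccc12` keeps that ring and alters one substituent on it: methyl in place of chloro on an aromatic carbon. Within the data shown here, no measured step touches the chloro itself; the large step into compound 2 concerns the whole ring, so it offers little guidance for one substituent exchanged on that ring. With nothing measured to suggest otherwise, the expected step of a 1.2-fold higher number from compound 2 to compound 3 (0.09 log units; within the scatter) is none beyond the scatter. Compound 3 is therefore estimated at 2500 nM in this assay, with a range from 800 nM to 8000 nM.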

Compound 3, half-maximal effective concentration: 5550 nM
Compound 3: the middle estimate sits 2.2-fold (0.35 log units) below what was measured, and the stated range covers the measured number.
By their numbers in this assay, from the lowest: compound 2; then compound 3; then compound 1.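

The identity of this one substituent matters: in this assay, a 2.7-fold higher number from compound 2 to compound 3 (0.43 log units; beyond the scatter), a modest change beyond the scatter from exchanging a single atom on the ring for another. The ring also does not depend on chloro for its large advantage over the open chain, since 2-methylphenyl in place of sec-butyl still gives a 32-fold lower number from compound 1 to compound 3 (1.50 log units; beyond the scatter), and the chloro ring gives an 87-fold lower number from compound 1 to compound 2 (1.94 log units; beyond the scatter). Nothing available on these compounds accounts for the difference between chloro and methyl.

With only two substituents compared at this place, no trend can yet be drawn from them. Going by these compounds, whether a fluoro, a methoxy, an amine or a carboxylic acid here would give a lower or a higher number remains open, as does whether a ring carrying no substituent would keep the advantage over sec-butyl.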